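This account rests on a few compounds, and the source may have more. Where it says the series, first, only, none or still open, it means among the compounds named here.

Of the compounds shown here, two sharing one core have been measured in a functional assay on MCF7 cells (Homo sapiens) for cytotoxicity, read by MTT assay, with a stated time of 72 h; on this read-out higher numbers stand for weaker inhibition and lower numbers for stronger inhibition. Compound 1 `COc1ccc(OC)c(/C=C/C(=O)Nc2cc3c(Nc4ccc(F)c(Cl)c4)ncnc3cc2O[C@H]2CCOC2)c1` gives 36300 nM in this assay. Compound 2 `COc1ccc(/C=C/C(=O)Nc2cc3c(Nc4ccc(F)c(Cl)c4)ncnc3cc2O[C@H]2CCOC2)c(OC)c1` gives 28600 nM in this assay. Among the compounds with values here, the single measured step between them, a 1.3-fold lower number from compound 1 to compound 2 (0.10 log units; within the scatter), lies within the scatter. Within the data shown here, compound 2 therefore stands at the lower of the two numbers, with compound 1 its only neighbour, and the two are within the scatter of each other.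

Compound 3 `O=C(/C=C/c1ccccc1[N+](=O)[O-])Nc1cc2c(Nc3ccc(F)c(Cl)c3)ncnc2cc1O[C@H]1CCOC1` has not been measured. It differs from compound 2 as follows: 2-nitrophenyl in place of 2,4-dimethoxyphenyl on a double-bonded chain carbon bound to a double-bonded chain carbon. Among the measured compounds shown here, no measured step bears directly on this change. For the measured compounds named here, the only step available, a 1.3-fold lower number from compound 1 to compound 2 (0.10 log units; within the scatter), exchanges one dimethoxyphenyl for another and stays within the scatter, and neither measured compound carries a nitrophenyl group. With nothing pointing either way, the step to compound 3 is expected to be small, estimated at a 1.0-fold higher number from compound 2 to compound 3 (0.02 log units; within the scatter), with no direction the data can support. Compound 3 is accordingly expected to give about 30000 nM in this assay, with a range from 9000 nM to 100000 nM.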

Compound 3, half-maximal inhibitory concentration: 28400 nM
For compound 3 the middle estimate is 1.1-fold (0.02 log units) above the measured one; low and high end bracket the measured number.
By their numbers in this assay, from the lowest: compounds 3, 2 and 1 (each within the scatter of the next).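

In this assay, 2-nitrophenyl in place of 2,4-dimethoxyphenyl on a double-bonded chain carbon bound to a double-bonded chain carbon comes with a 1.0-fold lower number from compound 2 to compound 3 (0.00 log units; within the scatter), and 2-nitrophenyl in place of 2,5-dimethoxyphenyl at the same place comes with a 1.3-fold lower number from compound 1 to compound 3 (0.11 log units; within the scatter). The earlier step had only traded one dimethoxyphenyl for another, whereas these two steps put a group without methoxy substituents at this place, and the three compounds still lie within the scatter of one another. No measurement shown here accounts for this result.

Going by these compounds, it remains open whether any group at this place would separate from these three beyond the scatter, for example an unsubstituted phenyl, an aminophenyl or a carboxyphenyl. Also open, on these data alone, is whether moving the nitro group to another ring carbon, or replacing the 2-(2-nitrophenyl)ethenyl group with a longer chain, would change the number in this assay.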